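Series notes: methoxy to hydrogen, compound 3 to compound 4

The source may hold more compounds than are shown below. What is called first, only, known or untested is meant among the compounds shown, and "the series" means these compounds.

Measured compounds:
Compound 1 `Clc1ccc(-c2n[nH]cc2N2CCCNCC2)cc1`: in an assay on isolated protein for binding affinity to 5-hydroxytryptamine receptor 6 (Homo sapiens) (a higher number here means a weaker inhibitor, a lower number a stronger inhibitor), compound 1 gives 1090 nM.
Compound 2 `Fc1cccc(-c2n[nH]cc2N2CCCNCC2)c1`: in this assay compound 2 gives 841 nM.
Compound 3 `COc1cccc(-c2n[nH]cc2N2CCCNCC2)c1`: in this assay compound 3 gives > 10000 nM, which is a limit of the assay and not a number.

Compound 3 thus sits at the limit of > 10000 nM in this assay, at which 1 of the 3 values shown sits, the weakest end of what the assay reports, while compounds 1 and 2 lie within the scatter of each other.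

Compound 4 `c1ccc(-c2n[nH]cc2N2CCCNCC2)cc1` differs from compound 3 by hydrogen in place of methoxy on an aromatic carbon. For the measured compounds named here, the only measured step that bears on this change is an at least 11-fold higher number from compound 2 to compound 3 (1.07 log units; beyond the scatter), where putting the methoxy in cost at least that much. Taking the methoxy off again is expected to recover a step of about an at least 6.6-fold lower number from compound 3 to compound 4 (0.82 log units; beyond the scatter) in this assay, toward the level of compounds 1 and 2. Compound 4 is therefore estimated at 1500 nM, with a range of 500 nM to 5000 nM.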

Compound 4, inhibition constant: 3480 nM
Compound 4: middle estimate off by 2.3-fold (0.37 log units), on the low side; the measured number falls inside the stated range.
By their numbers in this assay, from the lowest: compounds 2 and 1 (each within the scatter of the next); then compound 4. At a limit, above all of these: compound 3.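

In this assay hydrogen on this aromatic carbon does not return to the level of the halogen compounds: hydrogen in place of fluoro gives a 4.1-fold higher number from compound 2 to compound 4 (0.62 log units; beyond the scatter) and hydrogen in place of chloro gives a 3.2-fold higher number from compound 1 to compound 4 (0.50 log units; beyond the scatter) in this series. Hydrogen therefore sits between the two halogen compounds and methoxy, so substitution on this ring can move the number in either direction. The methoxy step an at least 2.8-fold lower number from compound 3 to compound 4 (0.45 log units; beyond the scatter) is only a bound, not a size: the limit of > 10000 nM in this assay, at which 1 of the 4 values shown sits.

Going by these compounds, the true distance between methoxy and hydrogen stays open. So does whether an amine or a hydroxyl here would follow the halogens or the methoxy.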